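The source may report more compounds than this note shows. Statements on the series, on what has been measured and on what is new or still open speak of the compounds shown alone.

Working notes on the series. Compound 1 `Cn1cc(-c2cnc(NCc3c(F)ccc4c3CCO4)c3cn[nH]c(=O)c23)cn1` is measured in a physicochemical assay for lipophilicity, using the shake flask method, in phosphate buffer, measured as octanol-water partition, with a stated time of 30 min, at pH 7.4 (a higher number here means a more lipophilic compound, a lower number a more polar compound), at 2.7. Among the three numbers in hand it stands second highest: compound 2 `Fc1ccc2c(c1CNc1ncc(Oc3ccccc3)c3nncn13)CCO2` gives 3.5, which lies above compound 1 beyond the scatter, and compound 3 `COCCC(=O)Nc1cnc(NCc2c(F)ccc3c2CCO3)n2cnnc12` gives 1.4, which lies below compound 1 beyond the scatter. Within the data shown here, the one directly comparable step so far is a number 2.10 log units lower from compound 2 to compound 3 (beyond the scatter), a swap on a different core and of a different kind.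

Compound 4 `Cc1ncccc1-c1cnc(NCc2c(F)ccc3c2CCO3)c2cn[nH]c(=O)c12` is not yet measured. It differs from compound 1 in one place: 2-methylpyridin-3-yl in place of 1-methyl-1H-pyrazol-4-yl on an aromatic carbon

Among the measured compounds shown here, no measured pair in the set touches this change, so the only guide is the change itself. The group that enters carries one more heavy atom, one fewer hydrogen-bond acceptor and a six-membered ring in place of a five-membered one. That points to a modest rise in this assay for compound 4 relative to compound 1, not to a step of the size seen from compound 2 to compound 3. The expected step is a number 0.60 log units higher from compound 1 to compound 4 (beyond the scatter), a rise beyond the scatter but small. Compound 4 is accordingly estimated at 3.3, with a range from 2.8 to 3.8.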

Compound 4, distribution coefficient: 3
Estimate against measurement, compound 4: 0.30 log units above, within the range that was stated.
By their numbers in this assay, from the lowest: compound 3; then compounds 1 and 4 (each within the scatter of the next); then compound 2.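

Among these compounds, on the aromatic carbon para to a large group in the shared core, this assay gives a number 0.30 log units higher from compound 1 to compound 4 (within the scatter) for 2-methylpyridin-3-yl in place of 1-methyl-1H-pyrazol-4-yl, the first step that can be read at this position. At this position, therefore, a six-membered aromatic ring with 7 heavy atoms and 1 hydrogen-bond acceptor replaces a five-membered aromatic ring with 6 heavy atoms and 2 hydrogen-bond acceptors, and the two compounds cannot be told apart in this measurement. No measurement in hand bears on why the change leaves the two compounds within the scatter of each other.

The step also changes the ring size, the number of ring nitrogens and the placing of the methyl group together, so the compounds shown cannot assign any share of it to one of these features. Also open, on these data alone, is how a carboxylic acid, an amine or a longer chain on this same aromatic carbon of the core of compound 1 would read in this assay, since both groups seen here are methyl-bearing aromatic rings.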